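The source may hold more compounds than are shown below. What is called first, only, known or untested is meant among the compounds shown, and "the series" means these compounds.

Of the compounds shown here, two of a shared core have been tested in a functional assay on A-375 cells (Homo sapiens) for antiproliferative activity, read by MTT assay, with a stated time of 24 h, tested at 0.41 ug/mL (a lower number here means a weaker effect, a higher number a stronger effect of the compound at the concentration tested), so far. Compound 1 `Cc1ccc2nc(C(=O)Nc3c(F)cc(-c4cccc(F)c4)cc3F)c(C)c(O)c2c1` gives 1.35% in this assay, and compound 2 `CCc1ccc2nc(C(=O)Nc3c(F)cc(-c4cccc(F)c4)cc3F)c(C)c(O)c2c1` gives 3.56% in this assay. Within the data shown here, the only measured step, a number 2.2 percentage points higher from compound 1 to compound 2 (within the scatter), lies within the scatter, so the two numbers stand close together near the bottom of the scale and neither can be called stronger than the other.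

Compound 3 `Cc1c(C(=O)Nc2c(F)cc(-c3cccc(F)c3)cc2F)nc2ccc(C(F)(F)F)cc2c1O` differs from compound 2 by one change, (trifluoromethyl in place of ethyl on an aromatic carbon). Among the measured compounds shown here, no measured step involves a trifluoromethyl group, so nothing in the measured pair speaks directly to this change. For the measured compounds named here, the only guidance is that the one change made so far left this assay essentially unmoved, and both measured numbers sit close to zero.

Compound 3 is therefore expected to give about 3% in this assay, within -5% to 12%, a step of a number 0.6 percentage points lower from compound 2 to compound 3 (within the scatter) that would not exceed the scatter.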

Compound 3, a percentage reported as inhibition, at one concentration (the size of the read-out at that concentration, not a potency): 16.5%
Estimate against measurement, compound 3: 13.5 percentage points below, outside the stated range (above it).
By their numbers in this assay, from the lowest: compounds 1 and 2 (each within the scatter of the next); then compound 3.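

The swap between methyl and ethyl gave no readable change, but this aromatic carbon on the shared core is not indifferent to what it carries. In this assay, trifluoromethyl in place of ethyl gives (a number 12.9 percentage points higher from compound 2 to compound 3 (beyond the scatter)) and trifluoromethyl in place of methyl gives (a number 15.2 percentage points higher from compound 1 to compound 3 (beyond the scatter)), so both steps clear the scatter, though both are modest. Nothing available explains why this group raises the number.

The compounds shown leave open whether a chlorine atom, a nitrile or a methoxy group on this carbon would also raise the number, or whether the rise is particular to trifluoromethyl. The read-out also gives the size of the effect at one concentration only, so the potency of compound 3 remains an open question.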